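From Compound 3 to Compound 4: Methoxy on the Benzoyl

The source may report more compounds than this note shows. Statements on the series, on what has been measured and on what is new or still open speak of the compounds shown alone.

In a functional assay on A549 cells (Homo sapiens) for inhibition, read by MTT assay, with a stated time of 24 h (on this read-out higher numbers stand for weaker inhibition of growth and lower numbers for stronger inhibition of growth), compound 3 (`COc1ccc2c(c1)c(-c1nc3ccccc3n1C(=O)c1ccccc1)cn2C`) gives 16700 nM, within the scatter of compound 1 (`Cn1cc(-c2nc3ccccc3n2C(=O)c2ccccc2)c2ccccc21`) at 19600 nM, and the two sit together at the low end of the three numbers, while compound 2 (`Cn1cc(-c2nc3ccccc3n2C(=O)c2cccc(Br)c2)c2ccccc21`) gives 34200 nM. Compound 4 (`COc1ccc(C(=O)n2c(-c3cn(C)c4ccc(OC)cc34)nc3ccccc32)cc1`) turns the benzoyl of compound 3 into (4-methoxyphenyl)carbonyl, with methoxy in place of hydrogen on an aromatic carbon. Among the compounds with values here, two measured steps bear on this change. Methoxy in place of hydrogen elsewhere in the structure gave a 1.2-fold lower number from compound 1 to compound 3 (0.07 log units; within the scatter), and bromo in place of hydrogen on the benzoyl ring gave a 1.7-fold higher number from compound 1 to compound 2 (0.24 log units; within the scatter). Neither lies beyond the scatter, so no step beyond it is expected in this assay. Compound 4 is expected at 17000 nM, within an estimated range of 8000 nM to 35000 nM.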

Compound 4, concentration for 50% growth inhibition: 4900 nM
Estimate against measurement, compound 4: 3.5-fold (0.54 log units) above; the whole stated range lies above it.
By their numbers in this assay, from the lowest: compound 4; then compounds 3, 1 and 2 (each within the scatter of the next, the first and the last beyond it).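

In this assay, within the data shown here, methoxy in place of hydrogen on the benzoyl ring, para to a large group, gives a 3.4-fold lower number from compound 3 to compound 4 (0.53 log units; beyond the scatter), the first step here beyond the scatter. The same replacement on the other part of the structure stayed within it, with a 1.2-fold lower number from compound 1 to compound 3 (0.07 log units; within the scatter), so this change does not count equally at both places. Nothing shown here accounts for the step. The compounds leave open whether an amine or a carboxylic acid at this place would give a similar number, and whether the step would hold on the core of compound 1, without the other methoxy.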